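Exchanging isopropyl for methylsulfanyl in compound 2

The compounds below may be only part of what the source reports. "The series", "measured", "known", "first", "only" and "open" are said of these compounds alone.

In a functional assay (blood) for inhibition, with Homo sapiens as the target (on this read-out higher numbers stand for weaker inhibition and lower numbers for stronger inhibition), two compounds have been measured so far. Compound 1 (`OC1O[C@H](CO/N=C2\CCc3cc(Sc4cc(F)cc(C5CCOCC5)c4)ccc32)[C@H](O)[C@H](O)[C@H]1O`) gives > 2500 nM, which is a limit of the assay and not a number. Among the compounds with values here, compound 2 (`CC(C)/C(=N\O)c1ccc(Sc2cc(F)cc(C3CCOCC3)c2)cc1`) gives 300 nM, and this is the only actual number available.

The next compound, compound 3 (`CS/C(=N\O)c1ccc(Sc2cc(F)cc(C3CCOCC3)c2)cc1`), carries methylsulfanyl in place of isopropyl on a carbon with a double bond to nitrogen. Within the data shown here, no measured step in this assay shows what this exchange does, so no shift beyond the usual scatter is expected, in either direction, and the expectation rests on compound 2 at 300 nM. The expected change is a 1.2-fold higher number from compound 2 to compound 3 (0.07 log units; within the scatter). For compound 3 the estimated value is 350 nM, with an expected range from 120 nM to 1100 nM.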

Compound 3, half-maximal inhibitory concentration: 190 nM
Compound 3: the middle estimate sits 1.8-fold (0.27 log units) above what was measured, and the stated range covers the measured number.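

In this assay, within the data shown here, this is the first exchange that can be read between two compounds differing in one place: methylsulfanyl in place of isopropyl on a carbon with a double bond to nitrogen gives a 1.6-fold lower number from compound 2 to compound 3 (0.20 log units; within the scatter). The position therefore accepts methylsulfanyl, with one fewer heavy atom, a sulfur in place of carbon and one hydrogen-bond acceptor counted, without a shift beyond the usual scatter, which compound 1 could not show because it differs from compound 2 in more than one place. Nothing given here accounts for the size of this step.

The compounds shown leave open whether an amine, a methoxy group or a longer alkyl chain on this carbon would give a step beyond the scatter. They also leave open whether the same exchange would behave alike on a different core, as this single step is all that can be read.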